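The compounds below may be only part of what the source reports. "The series", "measured", "known", "first", "only" and "open" are said of these compounds alone.

Compound 1 `O=C(/C=C/c1ccc2c(c1)B(O)OC2)c1ccc(Br)cc1` and compound 2 `O=C(/C=C/c1ccc2c(c1)B(O)OC2)c1ccc(C(F)(F)F)cc1` share one core and differ only in a single group on the aromatic ring attached to the carbonyl. In a toxicity assay on MCF-10A cells (Homo sapiens) for cytotoxicity, read by MTT assay, with a stated time of 48 h (on this read-out lower numbers stand for stronger inhibition and higher numbers for weaker inhibition), compound 1 gives 27800 nM, and compound 2 gives 22300 nM. Going by the values given here, of the two numbers recorded, compound 1 sits at the upper end, but the only step to a neighbour is small: a 1.2-fold lower number from compound 1 to compound 2 (0.10 log units; within the scatter). Compound 3 `Nc1cccc(C(=O)/C=C/c2ccc3c(c2)B(O)OC3)c1` is not yet measured. Its change from compound 1 is 3-aminophenyl in place of 4-bromophenyl on a carbonyl carbon. Among the compounds with values here, the one measured step, from compound 1 to compound 2, swaps one group for another at the same place on that ring and moves the number by a 1.2-fold lower number from compound 1 to compound 2 (0.10 log units; within the scatter), a shift that does not exceed the scatter. That step does not contain an amino group, nor a change of position on the ring, so it bears on the new change only loosely. With nothing in the data pointing either way, the expected step in this assay is a 1.1-fold lower number from compound 1 to compound 3 (0.05 log units; within the scatter), that is, nothing beyond the scatter. Compound 3 is therefore estimated at 25000 nM, with a range from 9000 nM to 70000 nM.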

Compound 3, half-maximal inhibitory concentration: 19600 nM
Estimate against measurement, compound 3: 1.3-fold (0.11 log units) above; the range from low to high includes it.
By their numbers in this assay, from the lowest: compounds 3, 2 and 1 (each within the scatter of the next).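

In this assay, going by these compounds alone, putting 3-aminophenyl in place of 4-bromophenyl on the carbonyl carbon gives a 1.4-fold lower number from compound 1 to compound 3 (0.15 log units; within the scatter), so this position has now tolerated a larger change than the one between compound 1 and compound 2 without the number leaving the scatter. Here the entering group differs from the leaving one in more than a single substituent: bromine gives way to nitrogen, the attachment named on the ring changes from 4 to 3, and the counts go from no hydrogen-bond donor or acceptor to one of each, yet the compounds remain indistinguishable on this read-out. No information is available that would explain this outcome.

The compounds shown leave open how the amino group and the change from 4 to 3 each contribute, since they arrive together in compound 3 and 4-aminophenyl, which would separate them, is not among the compounds shown. They also leave open whether a different kind of group on this carbonyl carbon, such as a phenyl ring bearing a carboxylic acid or a longer chain in place of the ring, would move the number beyond the scatter.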